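The compounds below may be only part of what the source reports. "The series", "measured", "known", "first", "only" and "open" are said of these compounds alone.

Working notes on the series.

Of the compounds shown here, three have been measured in a functional assay on CCRF-CEM cells (Homo sapiens) for inhibition, read by cell counting, with a stated time of 3 days; a lower number here means a stronger inhibitor, a higher number a weaker inhibitor. Compound 1 `COc1ccc(-c2nn3cc(-c4cccc(N)c4)nc3s2)cc1OC` gives 14000 nM in this assay. Compound 2 `C=C(Br)C(=O)Nc1cccc(-c2cn3nc(-c4ccc(C)cc4)sc3n2)c1` gives 1700 nM. Compound 3 `C=C(Br)C(=O)Nc1cccc(-c2cn3c(-c4ccc(OC)cc4)csc3n2)c1` gives 500 nM. On these numbers compound 2 stands second highest of the three: compound 3 lies nearest, with a number lower than that of compound 2 by a gap beyond the scatter, and compound 1 lies furthest, with a number higher than that of compound 2 by a gap also beyond the scatter. Among the measured compounds shown here, no pair of measured compounds differs in a single place, so no measured step is available to guide the next change.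

The step under consideration runs from compound 2 to compound 4 `C=C(Br)C(=O)Nc1cccc(-c2cn3nc(-c4ccc(Cl)cc4)sc3n2)c1`, the change being (chloro in place of methyl on an aromatic carbon), on the 4-methylphenyl that becomes 4-chlorophenyl. For the measured compounds named here, no measured pair shows what such an exchange does in this assay. With nothing to go on but the value of compound 2 at 1700 nM, the expectation is a step of a 1.3-fold lower number from compound 2 to compound 4 (0.12 log units; within the scatter), most likely no change beyond the scatter and at most a modest shift toward a lower number. Compound 4 is therefore expected to give about 1300 nM in this assay, with a range from 450 nM to 4000 nM.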

Compound 4, half-maximal inhibitory concentration: 3200 nM
Compound 4: the middle estimate sits 2.5-fold (0.39 log units) below what was measured; the range from low to high includes it.
By their numbers in this assay, from the lowest: compound 3; then compounds 2 and 4 (each within the scatter of the next); then compound 1.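

The exchange of methyl for chloro on an aromatic carbon gives the series its first measured step: in this assay it amounts to a 1.9-fold higher number from compound 2 to compound 4 (0.27 log units; within the scatter) and so gives no separation between the two compounds. Among the compounds shown here, this position, para to a large group on a six-membered aromatic ring of carbon only, therefore carries either the 4-methylphenyl or the 4-chlorophenyl with no change beyond the scatter, which the earlier compounds, none of them differing in a single place, could not show. No measurement available here offers an explanation for this step, and this one pair supports no wider rule about the position.

The compounds shown leave open what happens in this assay when the same aromatic carbon carries a group of a different kind, such as an amine, a carboxylic acid or a longer chain, in place of the methyl or the chloro. They also leave open whether the exchange of methyl for chloro would read the same on the core of compound 3, where the shared groups are arranged differently.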